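Cytotoxicity of an acyl sulfonamide replacing the pyrrolidine chain

The source may hold more compounds than are shown below. What is called first, only, known or untested is meant among the compounds shown, and "the series" means these compounds.

Compound 1, `Cc1cc(C)cc(S(=O)(=O)c2c(C(=O)N[C@@H]3CCN(Cc4n[nH]c(=O)n4C)C3)[nH]c3ccc(Cl)cc23)c1`, gives 22400 nM in an ADME assay on MT4 cells (Homo sapiens) for cytotoxicity, read by MTT assay, with a stated time of 5 days; a lower number here means that less compound is tolerated, a higher number that more compound is tolerated.
Compound 2, `Cc1cc(C)cc(S(=O)(=O)c2c(C(=O)N[C@@H]3CCN(Cc4ccccc4F)C3)[nH]c3ccc(Cl)cc23)c1`, gives only a limit of the assay, > 231000 nM, in this assay.
Compound 3, `Cc1cc(C)cc(S(=O)(=O)c2c(C(=O)N[C@H]3CCN(Cc4cccnc4)C3)[nH]c3ccc(Cl)cc23)c1`, gives 22800 nM in this assay.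

Compound 3 holds the highest of the two numbers measured, but its nearest neighbour, compound 1, lies within the scatter of it, so the two cannot be ordered. Compound 2 is reported only as a limit in this assay.

Compound 4 is `Cc1cc(C)cc(S(=O)(=O)c2c(C(=O)NS(=O)(=O)c3ccc(F)cc3F)[nH]c3ccc(Cl)cc23)c1`. Its difference from compound 3 is (2,4-difluorophenyl)sulfonyl in place of 1-((pyridin-3-yl)methyl)pyrrolidin-3-yl on an amide-type nitrogen.

For the measured compounds named here, the single measured step, an at least 10-fold higher number from compound 1 to compound 2 (1.01 log units; beyond the scatter), exchanges the group carried on the pyrrolidine nitrogen while the pyrrolidine itself stays. The change to compound 4 removes the pyrrolidine together with its nitrogen and installs a sulfonyl group directly on the amide-type nitrogen, so that step does not bear directly on it. Going by the values given here, it shows only that a change in this part of the molecule can move the number far, and the limit of > 231000 nM in this assay, at which 1 of the 3 values shown sits, shows how far the assay can report. No direction can therefore be expected with confidence for a 2.6-fold higher number from compound 3 to compound 4 (0.42 log units; beyond the scatter), and the estimate is kept wide. Compound 4 is estimated at 60000 nM, between 15000 nM and 240000 nM.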

Compound 4, half-maximal cytotoxic concentration: 121000 nM
Compound 4: the middle estimate sits 2.0-fold (0.30 log units) below what was measured; low and high end bracket the measured number.
By their numbers in this assay, from the lowest: compounds 1 and 3 (each within the scatter of the next); then compound 4. At a limit, above all of these: compound 2.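

In this assay, the exchange at this amide-type nitrogen gives a 5.3-fold higher number from compound 3 to compound 4 (0.72 log units; beyond the scatter), a modest step. Until now only the group carried on the pyrrolidine nitrogen had been varied, whereas here the whole 1-((pyridin-3-yl)methyl)pyrrolidin-3-yl group, with its basic-looking name set aside and its defined stereocentre gone, leaves and (2,4-difluorophenyl)sulfonyl enters, and more compound is tolerated, not less. So the pyrrolidine is not required for a high number in this assay, and the number can be moved at the amide-type nitrogen itself as well as further out on the chain; compound 2 remains the only compound reported as a limit of the assay, which is not a number: the limit of > 231000 nM in this assay, at which 1 of the 4 values shown sits.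

The compounds shown leave open which part of the entering group carries the step, the sulfonyl or the difluorinated ring. They also leave open how a methylsulfonyl group, an unsubstituted phenylsulfonyl group or a benzoyl group would stand on this nitrogen, and whether an open amine chain in place of the pyrrolidine would keep the number of compound 3.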